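Trimming One Ester from a Nucleoside Analogue

This account rests on a few compounds, and the source may have more. Where it says the series, first, only, none or still open, it means among the compounds named here.

Compound 1 `CCCC(CCC)C(=O)OC[C@H]1O[C@@H](n2cnc3c(N)ncnc32)[C@H](OC(=O)C(CCC)CCC)[C@]1(C)O` carries two (1-propylbutyl)carbonyl esters on its shared core. Among the measured compounds shown here, in a functional assay on Caco-2 cells (Homo sapiens) for inhibition, read by MTT assay, with a stated time of 48 h (on this read-out lower numbers stand for stronger inhibition and higher numbers for weaker inhibition), compound 1 gives 55100 nM, the only number obtained so far. Compound 2 `CCCC(CCC)C(=O)Nc1ncnc2c1ncn2[C@@H]1O[C@H](COC(=O)C(CCC)CCC)[C@@](C)(O)[C@H]1OC(=O)C(CCC)CCC`, a close relative, has no number in this assay, where its entry reads "nd(insoluble)" (no result reported); it did not dissolve. Compound 3 `CCCC(CCC)C(=O)OC[C@H]1O[C@@H](n2cnc3c(N)ncnc32)[C@H](O)[C@]1(C)O` differs from compound 1 in one place: hydrogen in place of (1-propylbutyl)carbonyl on an oxygen on a saturated carbon. For the measured compounds named here, no measured pair shows the size of such a step, so the expectation is a step from compound 1 to compound 3 of a 1.6-fold higher number from compound 1 to compound 3 (0.21 log units; within the scatter), toward weaker inhibition, close to the edge of the usual scatter. Compound 3 is therefore estimated at 90000 nM, with a range from 30000 nM to 270000 nM.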

Compound 3, half-maximal inhibitory concentration: > 200000 nM
Compound 3: a limit, no number; the forecaster's own chance of this, stated with the estimate: 30%; middle value at least 2.2-fold (0.34 log units) from the limit.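

Compound 3 reads > 200000 nM in this assay, which is a limit of the assay and not a number. Replacing the (1-propylbutyl)carbonyl on this oxygen with hydrogen gives an at least 3.6-fold higher number from compound 1 to compound 3 (0.55 log units; beyond the scatter), so this ester matters to the read-out, and losing it weakens inhibition. Only a minimum for that step can be read: the limit of > 200000 nM in this assay, at which 1 of the 3 values shown sits.

As far as these compounds go, whether a smaller ester such as acetyl, or an ester with a longer chain, would restore inhibition at this oxygen remains open. From the compounds shown here alone, the effect of changing the other ester also remains open.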